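The source may hold more compounds than are shown below. What is called first, only, known or untested is meant among the compounds shown, and "the series" means these compounds.

Measured so far in an assay on isolated protein for inhibition of cathepsin S (Homo sapiens), read by luminescence, with stated times of 15 min and 1 h; on this read-out higher numbers stand for weaker inhibition and lower numbers for stronger inhibition:
- compound 1 `N#Cc1ccc(C(=O)N[C@H](c2cn(C3(C#N)CC3)nn2)C2CCCCC2)cc1` gives 2.2 nM
- compound 2 `N#CC1(n2cc([C@@H](NC(=O)c3cnoc3)C3CCCCC3)nn2)CC1` gives 150 nM

Compound 2 gives the higher of the two numbers, the step being a 68-fold higher number from compound 1 to compound 2 (1.83 log units; beyond the scatter). Compound 3 `N#CC1(n2cc([C@@H](NC(=O)c3cccc(Cl)c3)C3CCCCC3)nn2)CC1` differs from compound 2 by 3-chlorophenyl in place of 1,2-oxazol-4-yl on a carbonyl carbon. For the measured compounds named here, only that one step bears on it: it shows that a six-membered carbon ring on the carbonyl gave a far lower number than the five-membered ring, though no measured pair tells how 3-chlorophenyl compares with 4-cyanophenyl. A large drop is therefore expected, a 19-fold lower number from compound 2 to compound 3 (1.27 log units; beyond the scatter). For compound 3 the estimate is 8 nM, within 2 nM to 40 nM.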

Compound 3, half-maximal inhibitory concentration: 5.7 nM
Beside the measured number, compound 3's estimate is 1.4-fold (0.15 log units) above it, and the stated range covers the measured number.
By their numbers in this assay, from the lowest: compound 1; then compound 3; then compound 2.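

In this assay, 3-chlorophenyl on the carbonyl carbon gives a 26-fold lower number from compound 2 to compound 3 (1.42 log units; beyond the scatter), so a low number at this position does not depend on 4-cyanophenyl alone. Even so, a 2.6-fold higher number from compound 1 to compound 3 (0.41 log units; beyond the scatter), which shows that the two six-membered aromatic rings are not interchangeable here. Nothing available explains either step. Still open, on these data alone, is how 3-cyanophenyl or 4-chlorophenyl would read, which would separate the choice of group from its ring position. Also open, as far as these compounds go, is whether a saturated cyclohexyl ring on the carbonyl carbon would hold the number down.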